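The source may report more compounds than this note shows. Statements on the series, on what has been measured and on what is new or still open speak of the compounds shown alone.

As far as these compounds go, in a functional assay on HeLa cells (Homo sapiens) for antiproliferative activity, read by MTT assay, with a stated time of 48 h (on this read-out lower numbers stand for stronger inhibition and higher numbers for weaker inhibition), compound 2 `COc1cccc(Nc2ncc(C)c(Nc3nc4ccccc4s3)n2)c1` gives only a limit of the assay, > 50000 nM, so how weak it truly is remains open. This is the limit of > 50000 nM in this assay, at which 1 of the 2 values shown sits. Compound 1 `CS(=O)(=O)c1ccc(Nc2nccc(Nc3nc4ccc(F)cc4s3)n2)cc1` gives 560 nM in this assay, but it differs from compound 2 in more than one place, so its value cannot be read as a step toward compound 3. Compound 3 `Cc1cnc(Nc2cccc(F)c2)nc1Nc1nc2ccccc2s1` differs from compound 2 by fluoro in place of methoxy on an aromatic carbon. Going by the values given here, no measured step of this kind is available, so little movement beyond the scatter is expected, and compound 3 is estimated at 40000 nM, within 8000 nM to 200000 nM, the expected step being an at least 1.2-fold lower number from compound 2 to compound 3 (0.09 log units; that floor lies within the scatter).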

Compound 3, half-maximal inhibitory concentration: 16300 nM
For compound 3 the middle estimate is 2.5-fold (0.39 log units) above the measured one; the measured number falls inside the stated range.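

In this assay, fluoro in place of methoxy on this aromatic carbon gives an at least 3.0-fold lower number from compound 2 to compound 3 (0.48 log units; beyond the scatter), the first step seen at this position. Fluoro therefore yields a true number here, where methoxy gave none. The real size of the step stays unknown because compound 2 has only a limit and not a number: the limit of > 50000 nM in this assay, at which 1 of the 3 values shown sits.

As far as these compounds go, whether an amine or a carboxylic acid at this place would lower the number further remains open. So does whether the same swap would act alike on the core of compound 1.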